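The source may hold more compounds than are shown below. What is called first, only, known or untested is meant among the compounds shown, and "the series" means these compounds.

Of the compounds shown here, three built on one shared core have been measured in an assay on membranes from HEK293 cells for displacement of a labelled ligand from adenosine receptor A2b (Homo sapiens), read by scintillation counting, with a stated time of 30 min; on this read-out higher numbers stand for weaker inhibition and lower numbers for stronger inhibition. Compound 1 `CCCOC(=O)C1=C(C)NC(=O)NC1c1ccsc1` gives 201 nM, compound 2 `CC1=C(C(=O)OC2CCC2)C(c2ccoc2)NC(=O)N1` gives 307 nM, and compound 3 `CC1=C(C(=O)OC2CCC2)C(c2cccs2)NC(=O)N1` gives 1090 nM, the highest number of the three and therefore the weakest inhibitor here. For the measured compounds named here, the only single-point step so far is a 3.6-fold higher number from compound 2 to compound 3 (0.55 log units; beyond the scatter), where the attached ring changed from furan-3-yl to thiophen-2-yl. Compound 4 `CC1=C(C(=O)OC2CCC2)C(c2ccsc2)NC(=O)N1` differs from compound 3 by thiophen-3-yl in place of thiophen-2-yl on a saturated ring carbon. Going by the values given here, no measured step makes exactly this change, but compound 1 also carries thiophen-3-yl and sits low in the set, while the move to thiophen-2-yl raised the number. Compound 4 is thus expected to give about 300 nM, in the range 120 nM to 800 nM. The expected step is a 3.6-fold lower number from compound 3 to compound 4 (0.56 log units; beyond the scatter).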

Compound 4, inhibition constant: 405 nM
Compound 4: middle estimate off by 1.4-fold (0.13 log units), on the low side; measured number inside the range.
By their numbers in this assay, from the lowest: compounds 1, 2 and 4 (each within the scatter of the next); then compound 3.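

Thiophen-3-yl in place of thiophen-2-yl gives a 2.7-fold lower number from compound 3 to compound 4 (0.43 log units; beyond the scatter) and so shows that, on this saturated ring carbon, the point at which the same ring is attached matters, not only which ring it is. Thiophen-3-yl in place of furan-3-yl gives a 1.3-fold higher number from compound 2 to compound 4 (0.12 log units; within the scatter) and cyclobutyl in place of propyl gives a 2.0-fold higher number from compound 1 to compound 4 (0.30 log units; within the scatter) so neither of these two changes moves the number beyond the scatter. No measurement here explains these differences. Still open, from the compounds shown here alone, is whether furan-2-yl would raise the number as thiophen-2-yl does, and how phenyl would compare at this carbon.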